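Compound 1 to compound 3: moving the pyridine nitrogen

The source may report more compounds than this note shows. Statements on the series, on what has been measured and on what is new or still open speak of the compounds shown alone.

Values in an ADME assay on L02 cells (Homo sapiens) for cytotoxicity, read by MTT assay, with a stated time of 24 h; on this read-out higher numbers stand for weaker inhibition and lower numbers for stronger inhibition:
compound 1 `O=C1/C(=C/c2cccnc2)CN(S(=O)(=O)c2ccc(Br)cc2)C/C1=C\c1ccccc1F`: 14600 nM
compound 2 `N#Cc1ccc(S(=O)(=O)N2C/C(=C\c3cccnc3)C(=O)/C(=C/c3ccccc3F)C2)cc1`: > 20000 nM, a limit

Among the measured compounds shown here, compound 1 carries the only actual number in this assay so far. Compound 2 sits at the limit of > 20000 nM in this assay, at which 1 of the 2 values shown sits.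

Compound 3 `O=C1/C(=C/c2ccncc2)CN(S(=O)(=O)c2ccc(Br)cc2)C/C1=C\c1ccccc1F` has the same atoms as compound 1, joined differently: pyridin-4-yl in place of pyridin-3-yl on a double-bonded chain carbon bound to a double-bonded ring carbon. For the measured compounds named here, the one measured step, an at least 1.3-fold higher number from compound 1 to compound 2 (0.13 log units; that floor lies within the scatter), is a change of another group, with the pyridin-3-yl left in place. Going by the values given here, no measured step covers a change of pyridin-3-yl itself, so the series offers no direct guide to this exchange. No shift beyond the scatter is therefore expected in this assay. The expected change is a 1.0-fold lower number from compound 1 to compound 3 (0.02 log units; within the scatter). Compound 3 is estimated at 14000 nM, with an expected range of 7000 nM to 28000 nM.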

Compound 3, half-maximal inhibitory concentration: 19400 nM
Compound 3: the middle estimate sits 1.4-fold (0.14 log units) below what was measured, within the range that was stated.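

In this assay, among the compounds shown here, this is the first measured exchange of the pyridine on a double-bonded chain carbon bound to a double-bonded ring carbon: pyridin-4-yl in place of pyridin-3-yl gives a 1.3-fold higher number from compound 1 to compound 3 (0.12 log units; within the scatter). Compound 1 and compound 3 therefore cannot be told apart on this read-out, and this place now has a direct measurement, whereas the earlier step covered only cyano in place of bromo. Nothing measured in the set accounts for the size of this step.

Still open, from the compounds shown here alone, is whether a different group at this place, such as a phenyl ring carrying an amine or a carboxylic acid, would give a shift beyond the scatter. Also open, going by these compounds, is how pyridin-4-yl would read alongside cyano, with compound 2 held only at a limit.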